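Isopropyl on the amidine: moving a change between two cores

This account rests on a few compounds, and the source may have more. Where it says the series, first, only, none or still open, it means among the compounds named here.

Of the compounds shown here, three of one series have been tested in an ADME assay on L6 cells (Rattus norvegicus) for cytotoxicity, read by resazurin assay, with a stated time of 70 h; a lower number here means a stronger inhibitor, a higher number a weaker inhibitor. Compound 1 `N=C(N)c1ccc2cc(-c3cccc(OCCCCOc4ccccc4)c3)oc2c1` gives 7600 nM. Compound 2 `CC(C)NC(=N)c1ccc2cc(-c3cccc(OCCCCOc4ccccc4)c3)oc2c1`, which carries an isopropyl in place of hydrogen on an amine nitrogen, gives 46500 nM. That single change made a 6.1-fold higher number from compound 1 to compound 2 (0.79 log units; beyond the scatter), so the isopropyl made the compound a weaker inhibitor of these cells.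

Compound 3 `N=C(N)c1ccc2oc(-c3ccc(OCCCCOc4ccccc4)cc3)cc2c1` has the same atoms as compound 1 joined differently; the difference between the two cores is not broken down here. In this assay compound 3 gives 1300 nM, the lowest of the three numbers and beyond the scatter from both others.

Compound 4 `CC(C)NC(=N)c1ccc2oc(-c3ccc(OCCCCOc4ccccc4)cc3)cc2c1` has not yet been measured. It stands to compound 3 exactly as compound 2 stands to compound 1: an isopropyl in place of hydrogen on an amine nitrogen, and the surroundings of that nitrogen are described in the same words for both pairs, so it is the same change. Among the measured compounds shown here, the expectation rests on the one measured instance, because a 6.1-fold higher number from compound 1 to compound 2 (0.79 log units; beyond the scatter) shows what the isopropyl did on the other core. The step from compound 3 to compound 4 is therefore estimated at a 6.2-fold higher number from compound 3 to compound 4 (0.79 log units; beyond the scatter). Compound 4 is expected to give about 8000 nM. For compound 4 the estimated range runs from 3000 nM to 20000 nM, allowing for the chance that the core change alters how the isopropyl acts.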

Compound 4, half-maximal inhibitory concentration: 6900 nM
Compound 4: middle estimate off by 1.2-fold (0.06 log units), on the high side; low and high end bracket the measured number.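

In this assay, putting isopropyl in place of hydrogen on the amine nitrogen gave a 5.3-fold higher number from compound 3 to compound 4 (0.72 log units; beyond the scatter), so the change that weakened compound 1 also weakened compound 3, and the second core behaved like the first. Set side by side, the two steps agree, which means that in this series the effect of this one change could be carried from one core to the other without a measurable loss in size: the same change on two cores in this assay, a 6.1-fold higher number (0.79 log units; beyond the scatter) from compound 1 to compound 2 and a 5.3-fold higher number (0.72 log units; beyond the scatter) from compound 3 to compound 4, 1.2-fold (0.06 log units) apart, within the scatter of two such steps

This agreement rests on just two pairs of compounds and one assay, so it does not show that the step would hold on a third core or in a different assay, and it does not explain why the isopropyl raises the number.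

The compounds shown leave open whether a methyl or a cyclopentyl on the same amine nitrogen would give a step of similar size to that of the isopropyl. They also leave open whether the step would survive if the four-carbon chain linking the two oxygens were replaced by a longer chain.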